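Swapping nitro for cyano on the aryl ring of compound 3

The compounds below may be only part of what the source reports. "The series", "measured", "known", "first", "only" and "open" are said of these compounds alone.

Measured compounds and their values:
compound 1 `CCCCCCCCCCCCCCCCCCNC(=O)[C@H]1CSC(c2cccnc2)N1` 7500 nM
compound 2 `CCCCCCCCCCCCCCCCCCNC(=O)[C@H]1CSC(c2ccc(N(C)C)cc2)N1` 5300 nM
compound 3 `CCCCCCCCCCCCCCCCCCNC(=O)[C@H]1CSC(c2ccc([N+](=O)[O-])cc2)N1` 15300 nM

All three share one core and were tested in a functional assay on DU-145 cells (Homo sapiens) for antiproliferative activity, read by sulforhodamine B assay; a higher number here means a weaker inhibitor, a lower number a stronger inhibitor. Compound 3 gives the highest number of the three in this assay: the step of a 2.0-fold higher number from compound 1 to compound 3 (0.31 log units; beyond the scatter) is modest but beyond the scatter, and the step of a 2.9-fold higher number from compound 2 to compound 3 (0.46 log units; beyond the scatter) is somewhat larger. By contrast, the step of a 1.4-fold lower number from compound 1 to compound 2 (0.15 log units; within the scatter) lies within the scatter.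

Compound 4 `CCCCCCCCCCCCCCCCCCNC(=O)[C@H]1CSC(c2ccc(C#N)cc2)N1` differs from compound 3 by one change: cyano in place of nitro on an aromatic carbon. Going by the values given here, no measured step tests a cyano group directly. The closest guide is the step of a 2.9-fold higher number from compound 2 to compound 3 (0.46 log units; beyond the scatter), in which a nitro group replaced a different substituent at the same place and the number rose by a modest amount. Since the nitro group now leaves again, a modest move toward a lower number is expected for compound 4, but only about the size of the steps seen so far, and possibly within the scatter. The estimated value for compound 4 in this assay is 9000 nM, with a likely range from 4000 nM to 20000 nM, which corresponds to an expected step of a 1.7-fold lower number from compound 3 to compound 4 (0.23 log units; within the scatter).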

Compound 4, half-maximal inhibitory concentration: > 20000 nM
Compound 4: a limit, no number; the forecaster's own chance of this, stated with the estimate: 10%; middle value at least 2.2-fold (0.34 log units) from the limit.
By their numbers in this assay, from the lowest: compounds 2 and 1 (each within the scatter of the next); then compound 3. At a limit, above all of these: compound 4.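

In this assay compound 4 gives no number, only a limit of the assay: the limit of > 20000 nM in this assay, at which 1 of the 4 values shown sits.

Replacing nitro with cyano on this aromatic carbon therefore did not lower the number, although the step, an at least 1.3-fold higher number from compound 3 to compound 4 (0.11 log units; that floor lies within the scatter), cannot be called a real rise on this evidence. The gaps to the other two compounds are clearer, an at least 3.7-fold higher number from compound 2 to compound 4 (0.57 log units; beyond the scatter) and an at least 2.6-fold higher number from compound 1 to compound 4 (0.42 log units; beyond the scatter), so the smaller cyano group does not restore the values of those two compounds.

On these data alone, how far compound 4 lies past its limit remains open, and so does the true size of all three steps. Also open, as far as these compounds go, is how a carboxylic acid or an amine would read on the same aromatic carbon, para to a large group.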